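The source may report more compounds than this note shows. Statements on the series, on what has been measured and on what is new or still open speak of the compounds shown alone.

Results so far in a physicochemical assay for solubility, with a stated time of 3 days, at pH 7; on this read-out higher numbers stand for higher solubility and lower numbers for lower solubility:

- compound 1 `NC(=O)c1ccc2[nH]c(-c3ccc(OCCCN4CCCCC4)cc3)nc2c1` gives > 400000 nM (a limit)
- compound 2 `CN1CCC(Oc2ccc(-c3nc4cc(C(N)=O)ccc4[nH]3)cc2)CC1` gives > 400000 nM (a limit)
- compound 3 `NC(=O)c1ccc2[nH]c(-c3ccc(OCC4CCCNC4)cc3)nc2c1` gives "not determined" (no result reported) (no result)

Compound 3 has no number of its own, so the step to compound 4 `NC(=O)c1ccc2[nH]c(-c3ccc(OCC4CCNCC4)cc3)nc2c1` has no measured starting point. The structural change is small: piperidin-4-yl in place of piperidin-3-yl on a saturated chain carbon bound to an oxygen on an aromatic ring. The two compounds have the same atoms, joined differently, and the change lies on a saturated chain carbon bound to an oxygen on an aromatic ring.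

Among the compounds with values here, only one measured step is available, a step that the two limits leave unreadable from compound 1 to compound 2. It involves a different pair of groups on the oxygen and gives no size that could be carried over. Within the data shown here, with no value for compound 3 and no readable step, no step of any particular size or direction can be expected in this assay.

What remains is the company compound 4 keeps, since it shares its core with compound 1 and compound 2. Both of those sit at the limit of > 400000 nM in this assay, at which 2 of the 3 values shown sit, so a result at that same limit seems the likeliest outcome. For compound 4 the expected value is about 400000 nM, with an estimated range of 200000 nM to 500000 nM.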

Compound 4, solubility: > 400000 nM
Compound 4 gave a limit, no number; the forecaster's own chance of this, stated with the estimate: 75%; the middle value sits exactly at the limit.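

The steps from compound 1 and from compound 2 to compound 4 cannot be read, since each of these compounds gives a limit and not a number: the limit of > 400000 nM in this assay, at which 3 of the 4 values shown sit.

The compounds shown leave open how far these three differ in this assay, and how compound 3, with piperidin-3-yl in place of piperidin-4-yl, compares with compound 4.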